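Methyl in Place of Hydrogen: Tolerance on Vero Cells

The source may hold more compounds than are shown below. What is called first, only, known or untested is meant among the compounds shown, and "the series" means these compounds.

Compound 1 `COC(=O)c1cc(-c2cccc(NC(=O)c3ccc(/C=C/C(=O)c4cccc([N+](=O)[O-])c4)cc3)c2)on1`: > 40 ug/mL
Compound 2 `COC(=O)c1cc(-c2cccc(NC(=O)c3ccc(OCc4ccc(Cl)cc4)cc3)c2)on1`: > 80 ug/mL
Compound 3 `CCCOc1ccc(C(=O)/C=C/c2ccc(C(=O)O)cc2)cc1`: < 10 ug/mL

In an ADME assay on Vero cells (Chlorocebus sabaeus) for cytotoxicity, read by MTT assay, with a stated time of 72 h (a lower number here means that less compound is tolerated, a higher number that more compound is tolerated), compound 1 is known only as a limit, > 40 ug/mL, a limit at which one of the three values shown rests (the limit of > 40 ug/mL in this assay, at which 1 of the 3 values shown sits). Compound 2 likewise sits at a limit, > 80 ug/mL. Compound 3 sits at a limit of the opposite kind, < 10 ug/mL. Among the measured compounds shown here, no step between two measured compounds differing in a single place is available, so compound 1 gives only a floor for its own value. Compound 4 `COC(=O)c1cc(-c2cccc(NC(=O)c3ccc(/C=C/C(=O)c4ccc(C)c([N+](=O)[O-])c4)cc3)c2)on1` differs from compound 1 in one place: methyl in place of hydrogen on an aromatic carbon. Such a small addition is expected to shift this assay by no more than the scatter; the expected step is a step that the limit leaves unreadable from compound 1 to compound 4. Compound 4 is therefore estimated at 50 ug/mL, between 20 ug/mL and 120 ug/mL, and is expected most likely to be reported again only as a limit.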

Compound 4, half-maximal cytotoxic concentration: > 80 ug/mL
Compound 4 ended at the assay's limit; the forecaster's own chance of this, stated with the estimate: 70%; middle value at least 1.6-fold (0.20 log units) from the limit.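

Compound 1 and compound 4 are both known only as limits in this assay, and the step between them cannot be read. The compounds shown leave open whether methyl in place of hydrogen on an aromatic carbon changes tolerance at all.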